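Pyrazole amide in place of hydroxypyridine on the thiophene core

The source may report more compounds than this note shows. Statements on the series, on what has been measured and on what is new or still open speak of the compounds shown alone.

Measured compounds:
compound 1 `Cc1ccc(C(=O)Nc2sc3c(c2C(N)=O)CCOC3)s1` with 778 nM
compound 2 `CC1(C)Cc2c(sc(NC(=O)c3ccccc3O)c2C(N)=O)CO1` with 13 nM
compound 3 `CC1(C)Cc2c(sc(NC(=O)c3cccnc3O)c2C(N)=O)C(C)(C)O1` with 190 nM

All three were tested in an assay on cells for positive allosteric modulation of Cystic fibrosis transmembrane conductance regulator variant F508del (Homo sapiens), with stated times of 10 min and 7 s, in the presence of a further agent that is not named here; on this read-out higher numbers stand for an effect only at larger amounts of compound and lower numbers for an effect already at smaller amounts. Among them, compound 3 stands second highest: it gives 190 nM. Compound 1 gives 778 nM and compound 2 gives 13 nM; the gap from compound 3 to each of these two lies beyond the scatter, with compound 1 higher and compound 2 lower. Compound 2 is therefore the compound with the lowest number of the three, and compound 3 sits between the other two.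

Compound 4 `CC1(C)Cc2c(sc(NC(=O)c3ccn[nH]3)c2C(N)=O)C(C)(C)O1` has not yet been measured. It differs from compound 3 in one place: 1H-pyrazol-5-yl in place of 2-hydroxypyridin-3-yl on a carbonyl carbon. The amide and the shared core stay as they are; only the aromatic group on the carbonyl carbon changes, with a five-membered ring carrying one donor and one acceptor replacing a six-membered ring carrying one donor and two acceptors.

Among the compounds with values here, no step between measured compounds touches this change, so the account rests on the one measured value of compound 3. The step is expected to be a modest rise in the number, close to or just beyond the scatter, of size a 2.1-fold higher number from compound 3 to compound 4 (0.32 log units; beyond the scatter). Compound 4 is therefore estimated at 400 nM, with a range from 100 nM to 1600 nM.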

Compound 4, half-maximal effective concentration: 3 nM
Compound 4: middle estimate off by 130-fold (2.12 log units), on the high side; measured number below the stated range.
By their numbers in this assay, from the lowest: compound 4; then compound 2; then compound 3; then compound 1.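

In this assay, within the data shown here, placing 1H-pyrazol-5-yl in place of 2-hydroxypyridin-3-yl on a carbonyl carbon gives a 63-fold lower number from compound 3 to compound 4 (1.80 log units; beyond the scatter) and thus provides the first step in this set that isolates a single place, showing that the group on the carbonyl carbon can by itself move the number by a large margin while the amide and the shared core stay fixed. This pair also shows that neither the six-membered aromatic ring nor the oxygen of the leaving group is required for a low number on this core, since the entering five-membered ring has fewer heavy atoms and fewer hydrogen-bond acceptors and contains no oxygen. Nothing available here explains why this exchange has so large an effect.

The compounds shown leave open whether the ring hydrogen on nitrogen of the 1H-pyrazol-5-yl group matters, which a 1-methylpyrazol-5-yl, thiazol-5-yl or furan-2-yl group at the same place could test. They also leave open whether the same exchange would give a step of similar size on the other cores shown, as this one pair speaks only for the core of compound 3.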